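The source may hold more compounds than are shown below. What is called first, only, known or untested is meant among the compounds shown, and "the series" means these compounds.

Compound 3 `COc1ccc(/C=N\NC(=S)NC(C)(C)CCC[C@](C)(O)[C@@H]2CC=C(C)CC2)cc1` gives 76100 nM in a functional assay on PCO3 cells (Homo sapiens) for cytotoxicity, read by sulforhodamine B assay (on this read-out lower numbers stand for stronger inhibition of growth and higher numbers for weaker inhibition of growth), the highest of the two numbers shown there, while compound 1 `CC1=CC[C@@H]([C@@](C)(O)CCCC(C)(C)NC=S)CC1` gives 72000 nM, a gap within the scatter. Compound 2 `CC1=CC[C@@H]([C@@](C)(O)CCCC(C)(C)NC(=S)NN)CC1` reaches only a limit of the assay, > 100000 nM. Both measured steps, an at least 1.3-fold higher number from compound 1 to compound 2 (0.14 log units; that floor lies within the scatter) and an at least 1.3-fold lower number from compound 2 to compound 3 (0.11 log units; that floor lies within the scatter), rest on that limit of > 100000 nM in this assay, at which 1 of the 3 values shown sits, and have floors within the scatter. Compound 4 `CC1=CC[C@@H]([C@@](C)(O)CCCC(C)(C)NC(=S)N/N=C\c2ccc(N(C)C)cc2)CC1` differs from compound 3 by dimethylamino in place of methoxy on an aromatic carbon. Neither measured step touches this aromatic substituent, and neither is known to have left the scatter, so no step beyond the scatter is expected in this assay a 1.1-fold lower number from compound 3 to compound 4 (0.04 log units; within the scatter). Compound 4 is therefore expected to give about 70000 nM, with a range from 25000 nM to 200000 nM.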

Compound 4, concentration for total growth inhibition: > 100000 nM
Compound 4 gave a limit, no number (the forecaster's own chance of this, stated with the estimate: 30%); middle value at least 1.4-fold (0.15 log units) away from the limit.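

This is the only step among the compounds shown that touches the aromatic substituent, on a carbon para to a large group, and in this assay it reads an at least 1.3-fold higher number from compound 3 to compound 4 (0.11 log units; that floor lies within the scatter). The step rests on a limit of the assay, so only its floor can be read, and that floor does not separate dimethylamino from methoxy: the limit of > 100000 nM in this assay, at which 2 of the 4 values shown sit.

Going by these compounds, whether any group at this carbon moves the number beyond the scatter stays open. A hydroxyl group, a chlorine atom or a nitro group there could test this.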